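From Methyl to Isobutyl Ester: Compound 3 to Compound 4

The source may hold more compounds than are shown below. What is called first, only, known or untested is meant among the compounds shown, and "the series" means these compounds.

Of the compounds shown here, three have been measured in an assay on membranes from HEK293 cells for displacement of a labelled ligand from adenosine receptor A2b (Homo sapiens), read by scintillation counting, with a stated time of 30 min, tested at 1 uM; on this read-out lower numbers stand for less inhibition and higher numbers for more inhibition at the one concentration tested (going by the name of the read-out). Compound 1 `COC(=O)C1=C(C)N(C)C(=O)NC1c1ccoc1` gives 7%, compound 2 `CC1=C(C(=O)OCC(C)C)C(c2ccoc2)NC(=O)N1C` gives 1%, and compound 3 `COC(=O)C1=C(C)N(C)C(=O)NC1c1cccs1` gives 17%. Compound 3 carries the largest of the three numbers, but its separation from compound 1 is small: the step of a number 10 percentage points higher from compound 1 to compound 3 (within the scatter) lies within the scatter, while compound 3 lies beyond the scatter of compound 2.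

Compound 4 `CC1=C(C(=O)OCC(C)C)C(c2cccs2)NC(=O)N1C` differs from compound 3 by one change: isopropyl in place of hydrogen on a saturated chain carbon bound to an oxygen next to a carbonyl group. Within the data shown here, only one measured step bears on this change, namely a number 6 percentage points lower from compound 1 to compound 2 (within the scatter), which made the same replacement, isopropyl in place of hydrogen on a saturated chain carbon bound to an oxygen next to a carbonyl group, on the shared core of compound 1. That step was within the scatter, so a shift of similar size and direction in this assay is expected for compound 4, which is to say nothing beyond the usual scatter, leaning slightly downward.

Compound 4 is therefore expected to fall at about 11%, with a range of 0% to 22%, corresponding to an expected step of a number 6 percentage points lower from compound 3 to compound 4 (within the scatter).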

Compound 4, a percentage reported as inhibition, at one concentration (the size of the read-out at that concentration, not a potency): 2%
The estimate for compound 4 lay 9 percentage points above the measured number, within the range that was stated.
By their numbers in this assay, from the lowest: compounds 2, 4, 1 and 3 (each within the scatter of the next, the first and the last beyond it).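

On the thiophen-2-yl core, methoxycarbonyl to isobutoxycarbonyl now gives a step that clears the usual scatter, a number 15 percentage points lower from compound 3 to compound 4 (beyond the scatter), which the same change on the furan-3-yl core did not do. This does not show that the change acts differently on the two cores, as the two steps still agree with each other: the same change on two cores in this assay, a number 6 percentage points lower (within the scatter) from compound 1 to compound 2 and a number 15 percentage points lower (beyond the scatter) from compound 3 to compound 4, 9 percentage points apart, within the scatter of two such steps

The exchange of furan-3-yl for thiophen-2-yl can now also be read with the isobutoxycarbonyl group in place, where it gives a number 1 percentage points higher from compound 2 to compound 4 (within the scatter), and this step and the one read with the methoxycarbonyl group in place cannot be told apart: the same change on two cores in this assay, a number 10 percentage points higher (within the scatter) from compound 1 to compound 3 and a number 1 percentage points higher (within the scatter) from compound 2 to compound 4, 9 percentage points apart, within the scatter of two such steps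

What the compounds leave open is how the number would respond to other groups at this place, such as an ethyl or a longer chain on the oxygen, or a carboxylic acid in place of the ester. Going by these compounds, all four compounds were read at one concentration only, so these numbers give no potency for any of them, and how strongly each compound binds remains open.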